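The source may report more compounds than this note shows. Statements on the series, on what has been measured and on what is new or still open speak of the compounds shown alone.

In a functional assay on OVCAR-3 cells (Homo sapiens) for antiproliferative activity, read by MTT assay, with a stated time of 24 h (a higher number here means a weaker inhibitor, a lower number a stronger inhibitor), compound 1 `O=C(NNc1ccccc1Cl)c1cccc(NS(=O)(=O)c2cnc(O)nc2O)c1` gives 3350 nM. Compound 3 `CCCCOc1ccc(C(=O)NNC(=O)c2ccc(NS(=O)(=O)c3cnc(O)nc3O)cc2)cc1` gives 12800 nM, so compound 1 holds the lower of the two actual numbers, with a gap beyond the usual scatter. Compound 2 `O=C(NNc1ccc(F)cc1)c1ccccc1NS(=O)(=O)c1cnc(O)nc1O` reads > 20000 nM, which is a limit of the assay and not a number.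

Compound 4 `O=C(NNC(=O)c1cccc(NS(=O)(=O)c2cnc(O)nc2O)c1)c1cccc(Cl)c1` has not yet been measured. It departs from compound 1 by one change, (3-chlorophenyl)carbonyl in place of 2-chlorophenyl on an amine nitrogen. Among the measured compounds shown here, the only measured guide to such a group is compound 3, which also carries an aromatic carbonyl group on that nitrogen and stands at 12800 nM. That single comparison points toward a weaker inhibitor rather than a stronger one, though it is thin support. In this assay a moderate step to a higher number is therefore expected, estimated as a 2.4-fold higher number from compound 1 to compound 4 (0.38 log units; beyond the scatter). For compound 4 the expected value is 8000 nM, with an estimated range from 2500 nM to 20000 nM.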

Compound 4, half-maximal inhibitory concentration: 13500 nM
The estimate for compound 4 lay 1.7-fold (0.23 log units) below the measured number, within the range that was stated.
By their numbers in this assay, from the lowest: compound 1; then compounds 3 and 4 (each within the scatter of the next). At a limit, above all of these: compound 2.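

In this assay, the change from 2-chlorophenyl to (3-chlorophenyl)carbonyl on an amine nitrogen comes with a 4.0-fold higher number from compound 1 to compound 4 (0.61 log units; beyond the scatter), the first step shown between two compounds that differ in only one place. It shows that the group on this nitrogen is not indifferent: the entering group, which brings a carbonyl, goes with a higher number than the group it replaces. Nothing measured here accounts for the size or direction of this step.

The change joins two differences, so the compounds shown leave open whether the step goes with the carbonyl or with the move from 2-chlorophenyl to 3-chlorophenyl. They also leave open how a plain 3-chlorophenyl, an unsubstituted benzoyl or an acetyl group on that nitrogen would read.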